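Thiophen-3-yl for iodo on the shared core

This account rests on a few compounds, and the source may have more. Where it says the series, first, only, none or still open, it means among the compounds named here.

compound 1 `Cc1ncnc2c1c(I)cn2[C@@H]1O[C@H](CO)[C@@H](O)[C@H]1O`: 13300 nM
compound 2 `COc1nc(N)nc2c1c(-c1ccccc1)cn2[C@@H]1O[C@H](CO)[C@@H](O)[C@H]1O`: > 100000 nM
compound 3 `CNc1ncnc2c1c(I)cn2[C@@H]1O[C@H](CO)[C@@H](O)[C@H]1O`: > 100000 nM

Compound 1 is the only one of the three with a number in an ADME assay on MRC5 cells (Homo sapiens), read by MTT assay, with a stated time of 72 h (on this read-out lower numbers stand for stronger inhibition and higher numbers for weaker inhibition), where compound 1 gives 13300 nM. For compound 2 this assay reports only a limit, > 100000 nM. For compound 3 the read-out is likewise a limit, > 100000 nM. Among the measured compounds shown here, the one step between two measured compounds, an at least 7.5-fold higher number from compound 1 to compound 3 (0.87 log units; beyond the scatter), can be stated only as a bound because of the limit of > 100000 nM in this assay, at which 2 of the 3 values shown sit.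

Compound 4 `CNc1ncnc2c1c(-c1ccsc1)cn2[C@@H]1O[C@H](CO)[C@@H](O)[C@H]1O` keeps the methylamino group of compound 3 and differs from it by thiophen-3-yl in place of iodo on an aromatic carbon. For the measured compounds named here, no measured step bears on this exchange: compound 2 also carries an aromatic ring in this position but differs from compound 3 elsewhere as well, so its limit shows only that it, too, sits at the boundary of this assay. Compound 4 is therefore expected to stay at that boundary, with a step that the limit leaves unreadable from compound 3 to compound 4 that is not expected to exceed the scatter. The estimate for compound 4 is 150000 nM, within 50000 nM to 500000 nM.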

Compound 4, half-maximal inhibitory concentration: > 100000 nM
Compound 4: no number, only a limit; the forecaster's own chance of this, stated with the estimate: 75%; the middle value is on the limit's open side.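

No new step can be read between compound 3 and compound 4, because in this assay both give a limit and not a number: the limit of > 100000 nM in this assay, at which 3 of the 4 values shown sit.

The compounds shown leave open whether thiophen-3-yl in place of iodo on an aromatic carbon changes the read-out at all, and by how much.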